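Pentylsulfanyl in Place of Propylamino on the Shared Core

A few compounds are considered here, and "the series" means these few. Any claim that something is new, unique, unknown or untested is made for them only; others in the source may bear on it.

The series shares one core and varies a single substituent. Compound 1 `Cc1nc(N)c2nc(O)n(Cc3ccccc3)c2n1` carries a methyl there and in a functional assay on the whole organism for activation, with Mus musculus as the target (a higher number here means that more compound is needed for the effect, a lower number that less compound is needed), compound 1 gives 3 mg/kg. Compound 2 `CCCCCNc1nc(N)c2nc(O)n(Cc3ccccc3)c2n1` carries a pentylamino and gives 0.3 mg/kg. Compound 3 `CCCNc1nc(N)c2nc(O)n(Cc3ccccc3)c2n1` carries a propylamino and gives 1 mg/kg. Among the three numbers compound 3 stands second highest: a 3.0-fold lower number from compound 1 to compound 3 (0.48 log units; beyond the scatter), while a 3.3-fold higher number from compound 2 to compound 3 (0.52 log units; beyond the scatter).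

Compound 4 `CCCCCSc1nc(N)c2nc(O)n(Cc3ccccc3)c2n1` differs from compound 3 in one place: pentylsulfanyl in place of propylamino on an aromatic carbon. Going by the values given here, two measured steps bear on this. The chain length matters, since a 10-fold lower number from compound 1 to compound 2 (1.00 log units; beyond the scatter) and a 3.0-fold lower number from compound 1 to compound 3 (0.48 log units; beyond the scatter), and a 3.3-fold higher number from compound 2 to compound 3 (0.52 log units; beyond the scatter); compound 4 carries the longer chain of compound 2. Among the compounds with values here, the exchange of the nitrogen link for sulfur has no measured counterpart in this set, so its effect is unknown. Compound 4 is therefore expected to come out somewhat lower than compound 3, a 2.0-fold lower number from compound 3 to compound 4 (0.30 log units; within the scatter), because compound 2 with the same chain length gives 0.3 mg/kg, though with a widened range for the untested link. The estimate for compound 4 is 0.5 mg/kg, within 0.15 mg/kg to 2 mg/kg.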

Compound 4, minimum effective dose: 1 mg/kg
The estimate for compound 4 lay 2.0-fold (0.30 log units) below the measured number; the measured number falls inside the stated range.
By their numbers in this assay, from the lowest: compound 2; then compounds 3 and 4 (each within the scatter of the next); then compound 1.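

With the pentyl chain held fixed, exchanging the nitrogen link for sulfur in this assay gives a 3.3-fold higher number from compound 2 to compound 4 (0.52 log units; beyond the scatter), so the atom that joins the chain to the shared core matters at this position, and the chain alone does not set the outcome. Pentylsulfanyl does not separate from propylamino, with no change at the digits printed from compound 3 to compound 4 (within the scatter), although that pair differs in both chain and link, so the two contributions cannot be told apart from this step alone. Pentylsulfanyl still compares well with the small methyl group, with a 3.0-fold lower number from compound 1 to compound 4 (0.48 log units; beyond the scatter), and nothing available explains the effect of the sulfur link.

From the compounds shown here alone, whether the loss on moving from nitrogen to sulfur has the same size on a shorter chain remains open, and propylsulfanyl would be the direct test of that. It is also unknown how an oxygen-linked chain such as pentyloxy, or a longer chain such as heptylamino, would compare with pentylamino at this position.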